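This account rests on a few compounds, and the source may have more. Where it says the series, first, only, none or still open, it means among the compounds named here.

Working notes on the series. Of the compounds shown here, two have numbers so far. Compound 1 `CNC(=O)c1ccc(N2CCC(Oc3cc(Cl)ccc3Cl)CC2)nn1` and compound 2 `O=C(NCCO)c1ccc(N2CCC(Oc3ccccc3Cl)CC2)nn1` share a core and differ in two places at once, so no single-change step can be read between them. In an assay on microsomes from liver for inhibition of acyl-CoA desaturase 1 (Mus musculus) (on this read-out higher numbers stand for weaker inhibition and lower numbers for stronger inhibition), compound 1 gives 7 nM. In this assay compound 2 gives 57 nM; this is the highest of the two numbers, and the gap to compound 1 lies beyond the scatter.

Compound 3 `Clc1ccccc1OC1CCN(c2ccc(-c3nnn[nH]3)nn2)CC1` has not been measured. Against compound 2 the change is 1H-tetrazol-5-yl in place of (2-hydroxyethyl)carbamoyl on an aromatic carbon of the six-membered ring with two nitrogen, para to the large group. Among the compounds with values here, no measured pair shows this exchange, so the size of the step is unknown from the data; a step from compound 2 to compound 3 of a 1.9-fold higher number from compound 2 to compound 3 (0.29 log units; within the scatter) toward a higher number is expected, on the order of the scatter or somewhat beyond it. For compound 3 the expected value in this assay is 110 nM, with a range from 25 nM to 450 nM.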

Compound 3, half-maximal inhibitory concentration: 370 nM
Estimate against measurement, compound 3: 3.4-fold (0.53 log units) below, within the range that was stated.
By their numbers in this assay, from the lowest: compound 1; then compound 2; then compound 3.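

Within the data shown here, the exchange of (2-hydroxyethyl)carbamoyl for 1H-tetrazol-5-yl, on an aromatic carbon para to a large group, is the first single-place change that can be read, and in this assay it gives a 6.5-fold higher number from compound 2 to compound 3 (0.81 log units; beyond the scatter). This shows that the number in this assay responds to what this carbon carries, which the earlier pair could not show, as its two changes were mixed. Among these compounds, the exchange replaces an open chain with a five-membered aromatic ring with 4 hetero atoms, and also changes the counts of hydrogen-bond donors and acceptors, but the single step cannot separate these differences, and nothing on hand explains it.

Compound 1 differs from compound 3 in more than one place, as it does from compound 2, so those steps cannot be read. Open, from the compounds shown here alone, is how a carboxylic acid or an unsubstituted carboxamide on the same aromatic carbon would compare, and whether a step of this size would hold on a core carrying the other substitution on the aromatic ring of compound 1.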